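A few compounds are considered here, and "the series" means these few. Any claim that something is new, unique, unknown or untested is made for them only; others in the source may bear on it.

The measured compounds:
compound 1, `O=C(CCCCCCc1ccccc1)c1ncc(-c2ccccc2F)o1`, gives 110 nM in an assay (Rattus norvegicus) for inhibition of Fatty-acid amide hydrolase 1 (Homo sapiens); a lower number here means a stronger inhibitor, a higher number a weaker inhibitor;
compound 2, `Nc1ccc(-c2cnc(C(=O)CCCCCCc3ccccc3)o2)cc1`, gives 90 nM;
compound 3, `O=C(CCCCCCc1ccccc1)c1ncc(-c2ccc(O)cc2)o1`, gives 140 nM.

Compound 3 has the highest of the three numbers, but its steps to compound 1 and to compound 2 are both within the scatter. Compound 4, `Cc1ccnc(-c2cnc(C(=O)CCCCCCc3ccccc3)o2)c1`, differs from compound 3 by 4-methylpyridin-2-yl in place of 4-hydroxyphenyl on an aromatic carbon. Going by the values given here, the steps that bear on this change, all at the same place, are a 1.3-fold higher number from compound 1 to compound 3 (0.10 log units; within the scatter), a 1.6-fold higher number from compound 2 to compound 3 (0.19 log units; within the scatter) and a 1.2-fold lower number from compound 1 to compound 2 (0.09 log units; within the scatter), none of them beyond the scatter. Accordingly, no step beyond the scatter is expected in this assay. The expected step is no change at the digits printed from compound 3 to compound 4 (within the scatter). Compound 4 is estimated at 140 nM, with a range from 50 nM to 400 nM.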

Compound 4, inhibition constant: 0.6 nM
Compound 4: middle estimate off by 230-fold (2.37 log units), on the high side, and the stated range ends above it.
By their numbers in this assay, from the lowest: compound 4; then compounds 2, 1 and 3 (each within the scatter of the next).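

In this assay, going by these compounds alone, the aromatic carbon next to the ring oxygen had looked indifferent to the aryl group it carries, but 4-methylpyridin-2-yl gives a 230-fold lower number from compound 3 to compound 4 (2.37 log units; beyond the scatter) and also a 150-fold lower number from compound 2 to compound 4 (2.18 log units; beyond the scatter) and a 180-fold lower number from compound 1 to compound 4 (2.26 log units; beyond the scatter) as its steps from the earlier compounds. The position therefore does respond to this group, whose six-membered aromatic ring holds 1 hetero atom. No measurement shown accounts for the size of these steps. Going by these compounds, whether the ring nitrogen or the methyl carries the step stays open; a pyridin-2-yl without the methyl or a 4-methylphenyl would bear on that.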